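Benzothiophene in place of fluorophenyl on the carbonyl carbon

The source may report more compounds than this note shows. Statements on the series, on what has been measured and on what is new or still open speak of the compounds shown alone.

Of the compounds shown here, three sharing one core have been tested in an ADME assay on Huh-7 cells (Homo sapiens) for cytotoxicity; on this read-out lower numbers stand for higher toxicity in this test and higher numbers for lower toxicity in this test. Compound 1 `O=C(NC(=S)N1CCc2c(OCCCCCOc3ccc(Cl)cc3)cccc21)c1ccc([N+](=O)[O-])cc1` gives 13600 nM. Compound 2 `N#Cc1cccc(C(=O)NC(=S)N2CCc3c(OCCCCCOc4ccc(Cl)cc4)cccc32)c1` gives 9750 nM in this assay, and compound 3 `O=C(NC(=S)N1CCc2c(OCCCCCOc3ccc(Cl)cc3)cccc21)c1ccc(F)cc1` gives 31100 nM. Compound 3 stands highest of the three numbers: the step of a 2.3-fold higher number from compound 1 to compound 3 (0.36 log units; beyond the scatter) and the step of a 3.2-fold higher number from compound 2 to compound 3 (0.50 log units; beyond the scatter) both exceed the scatter, whereas the step of a 1.4-fold lower number from compound 1 to compound 2 (0.14 log units; within the scatter) does not.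

Compound 4 `O=C(NC(=S)N1CCc2c(OCCCCCOc3ccc(Cl)cc3)cccc21)c1cc2ccccc2s1` differs from compound 3 in one place: 1-benzothiophen-2-yl in place of 4-fluorophenyl on a carbonyl carbon. Going by the values given here, two measured steps exchange the group on the carbonyl carbon and therefore bear on this change, a 1.4-fold lower number from compound 1 to compound 2 (0.14 log units; within the scatter) and a 3.2-fold higher number from compound 2 to compound 3 (0.50 log units; beyond the scatter); both are modest at most, and none of the measured compounds carries a 1-benzothiophen-2-yl group, so the direction for compound 4 cannot be read from them directly. A step of modest size in this assay is expected, somewhat more likely towards a lower number than compound 3 shows, but possibly none beyond the scatter. Compound 4 is therefore estimated at 20000 nM, with a range from 7000 nM to 50000 nM. This estimate means an expected step of a 1.6-fold lower number from compound 3 to compound 4 (0.19 log units; within the scatter).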

Compound 4, half-maximal cytotoxic concentration: > 50000 nM
Compound 4 ended at the assay's limit; the forecaster's own chance of this, stated with the estimate: 10%; middle value at least 2.5-fold (0.39 log units) from the limit.
By their numbers in this assay, from the lowest: compounds 2 and 1 (each within the scatter of the next); then compound 3. At a limit, above all of these: compound 4.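

In this assay compound 4 gives a limit of the assay and not a number: the limit of > 50000 nM in this assay, at which 1 of the 4 values shown sits. Placing 1-benzothiophen-2-yl on the carbonyl carbon still separates compound 4 clearly from two of the earlier compounds, with an at least 5.1-fold higher number from compound 2 to compound 4 (0.70 log units; beyond the scatter) and an at least 3.6-fold higher number from compound 1 to compound 4 (0.56 log units; beyond the scatter), whereas an at least 1.6-fold higher number from compound 3 to compound 4 (0.20 log units; that floor lies within the scatter) leaves the true size of that step unknown. Going by these compounds alone, the earlier compounds carried only a single six-membered aromatic ring at this carbonyl carbon, and compound 4 shows that a group with one five-membered and one six-membered aromatic ring there does not bring the number down.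

Going by these compounds, how far compound 4 lies beyond the limit stays open, and with it whether compound 4 truly separates from compound 3 in this read-out. Also open, on these data alone, is whether the ring sulfur of the 1-benzothiophen-2-yl group has any part in this result, a question that a 1-benzofuran-2-yl or naphthalen-2-yl group on the same carbonyl carbon would address.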